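Adding a methyl to the 1H-pyrazol-4-yl group

The source may hold more compounds than are shown below. What is called first, only, known or untested is meant among the compounds shown, and "the series" means these compounds.

Compound 1 `CN1c2cc(-c3ccncc3)sc2C(=O)NC1(C)C` gives 140 nM in an assay for inhibition of Rho-associated protein kinase 1 (Homo sapiens), read by TR-FRET, with stated times of 5 min and 2 h; on this read-out higher numbers stand for weaker inhibition and lower numbers for stronger inhibition; compound 2 `CN1c2cc(-c3cn[nH]c3)sc2C(=O)NC1(C)C` gives 130 nM. For the measured compounds named here, with a 1.1-fold lower number from compound 1 to compound 2 (0.03 log units; within the scatter) inside the scatter, compound 2 stands at the lowest of the two numbers, the only other number, that of compound 1, within the scatter of it. Compound 3 `Cc1n[nH]cc1-c1cc2c(s1)C(=O)NC(C)(C)N2C` differs from compound 2 by methyl in place of hydrogen on an aromatic carbon. Going by the values given here, no measured step bears on this change; the one known step concerns a different group. No step beyond the scatter is therefore expected, and a 1.2-fold higher number from compound 2 to compound 3 (0.06 log units; within the scatter) is the estimated change. Compound 3 is expected at 150 nM, within 50 nM to 450 nM.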

Compound 3, half-maximal inhibitory concentration: 54 nM
Compound 3: the middle estimate sits 2.8-fold (0.44 log units) above what was measured, within the range that was stated.
By their numbers in this assay, from the lowest: compound 3; then compounds 2 and 1 (each within the scatter of the next).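

In this assay, for the compounds shown here, the change from 1H-pyrazol-4-yl to 3-methyl-1H-pyrazol-4-yl gives the first step beyond the scatter (a 2.4-fold lower number from compound 2 to compound 3 (0.38 log units; beyond the scatter)). The exchange of pyridin-4-yl for 1H-pyrazol-4-yl alone stayed within the scatter, whereas 3-methyl-1H-pyrazol-4-yl in place of pyridin-4-yl gives a modest step (a 2.6-fold lower number from compound 1 to compound 3 (0.41 log units; beyond the scatter)), so this ring carbon, next to the ring nitrogen, responds to methyl. No supporting data are available to explain the shift.

Open: whether ethyl, a longer chain or an amine on this carbon would lower the number further, and whether chlorine would match methyl.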